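Taking the methoxy group off compound 3

This account rests on a few compounds, and the source may have more. Where it says the series, first, only, none or still open, it means among the compounds named here.

Of the compounds shown here, three have been tested so far in a functional assay on B16-F10 cells (Mus musculus) for cytotoxicity, read by MTT assay, with a stated time of 72 h; on this read-out higher numbers stand for weaker inhibition and lower numbers for stronger inhibition. Compound 1 `c1ccc2[nH]c(-n3cccn3)cc2c1` gives > 100000 nM, and this is a limit of the assay, not a number. Compound 2 `Cc1ccc2[nH]c(-n3cccn3)c(C3=C(Br)C(=O)NC3=O)c2c1` gives 8000 nM. Compound 3 `COc1ccc2[nH]c3c4cn[nH]c4c4c(c3c2c1)C(=O)NC4=O` gives 37000 nM. Of the two real numbers, that of compound 3 is the higher, so it is the weaker of the pair, and the gap to compound 2 lies beyond the usual scatter.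

The next compound, compound 4 `O=C1NC(=O)c2c1c1[nH]ncc1c1[nH]c3ccccc3c21`, differs from compound 3 in a single place: hydrogen in place of methoxy on an aromatic carbon. It carries hydrogen in place of methoxy on an aromatic carbon, in a six-membered aromatic ring of carbon only that is part of a fused system of five rings.

Going by the values given here, no pair of measured compounds shows this change on its own, so the only firm anchor is compound 3 at 37000 nM. A small step is therefore expected, probably none beyond the scatter, with a slight lean towards a lower number. The expected step is a 1.3-fold lower number from compound 3 to compound 4 (0.12 log units; within the scatter). In this assay the estimated value for compound 4 is 28000 nM, with an expected range from 9000 nM to 85000 nM.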

Compound 4, half-maximal inhibitory concentration: 75000 nM
Beside the measured number, compound 4's estimate is 2.7-fold (0.43 log units) below it; low and high end bracket the measured number.
By their numbers in this assay, from the lowest: compound 2; then compound 3; then compound 4. At a limit, above all of these: compound 1.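

In this assay, removing the methoxy group from this aromatic carbon gives the first change in a single place among these compounds, and the number rises: a 2.0-fold higher number from compound 3 to compound 4 (0.31 log units; beyond the scatter). The step is modest but beyond the usual scatter, so at this position on the six-membered ring, methoxy goes with somewhat stronger inhibition than plain hydrogen, and the group cannot be dropped without a measurable cost in this pair. Compound 1 shows where the read-out runs out, a limit and not a number, so any further weakening from compound 4 could soon become impossible to size: the limit of > 100000 nM in this assay, at which 1 of the 4 values shown sits.

The compounds shown leave open whether a hydroxyl group, a chlorine atom or a longer ethoxy chain on this carbon would give a lower number than methoxy, and so whether the oxygen or the attached carbon matters more. This single pair also cannot say whether the same change would have a similar effect on a different core, such as that of compound 2.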